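Cyanocarbamoyl for Nitrile: Solubility Beyond a Shared Limit

This account rests on a few compounds, and the source may have more. Where it says the series, first, only, none or still open, it means among the compounds named here.

Measured compounds:
Compound 1, `CCOC(=O)c1nc(C)c2c(c1N)C(=O)N(Cc1ccccc1)C2=O`: < 5000 nM
Compound 2, `Cc1nc(C#N)c(N)c2c1C(=O)N(Cc1ccccc1)C2=O`: < 5000 nM
Compound 3, `Cc1nnc(-c2nc(C)c3c(c2N)C(=O)N(Cc2ccccc2)C3=O)o1`: < 5000 nM

In a physicochemical assay for solubility, using the shake flask method, in simulated intestinal fluid, measured as kinetic solubility, with a stated time of 2 h, at 25 degrees C, at pH 6.5 (a higher number here means a more soluble compound, a lower number a less soluble compound), compound 2 gives < 5000 nM, which is a limit of the assay and not a number. Compound 1 likewise sits at a limit, and compound 3 too, so every measured value here is the limit of < 5000 nM in this assay, at which 3 of the 3 values shown sit. The steps a step that the two limits leave unreadable from compound 1 to compound 2, a step that the two limits leave unreadable from compound 1 to compound 3 and a step that the two limits leave unreadable from compound 2 to compound 3 therefore tell nothing about size or direction.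

Compound 4, `Cc1nc(C(=O)NC#N)c(N)c2c1C(=O)N(Cc1ccccc1)C2=O`, differs from compound 2 in one place: cyanocarbamoyl in place of cyano on an aromatic carbon. Among the compounds with values here, no measured step in this assay involves a cyanocarbamoyl group, and the steps that exist are unreadable, so the data give no direction for this assay beyond the scatter.

For compound 4 the step of an at least 1.6-fold higher number from compound 2 to compound 4 (0.20 log units; that floor lies within the scatter) is estimated only loosely. Compound 4 is expected to give about 8000 nM in this assay, within a range from 2000 nM to 40000 nM, with a fair chance that only a limit is reported again.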

Compound 4, solubility: 185000 nM
For compound 4 the middle estimate is 23-fold (1.36 log units) below the measured one; measured number outside the range, above it.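

In this assay, this position on an aromatic carbon next to the ring nitrogen now gives its first readable result, after a run of values that were only a limit: the limit of < 5000 nM in this assay, at which 3 of the 4 values shown sit. Cyanocarbamoyl in place of the nitrile gives an at least 37-fold higher number from compound 2 to compound 4 (1.56 log units; beyond the scatter), and the two other comparisons agree, with an at least 37-fold higher number from compound 3 to compound 4 (1.56 log units; beyond the scatter) for cyanocarbamoyl in place of 5-methyl-1,3,4-oxadiazol-2-yl and an at least 37-fold higher number from compound 1 to compound 4 (1.56 log units; beyond the scatter) for cyanoamino in place of ethoxy on the carbonyl carbon. Cyanocarbamoyl is thus the only group shown here to clear that limit, while the steps among ethoxycarbonyl, cyano and 5-methyl-1,3,4-oxadiazol-2-yl cannot be read.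

As far as these compounds go, what a plain carboxamide or a carboxylic acid would give at this position stays open. From the compounds shown here alone, with it stays open whether the terminal cyano of the new group matters at all.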